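From Methyl to Propyl Ester: A Small Chain Extension

The source may report more compounds than this note shows. Statements on the series, on what has been measured and on what is new or still open speak of the compounds shown alone.

Going by the values given here, compound 2 `COC(=O)C1=C(C)NC(=S)NC1c1ccoc1` is one of two compounds measured in an assay on membranes from CHO cells for displacement of a labelled ligand from adenosine receptor A1 (Homo sapiens), read by scintillation counting, with a stated time of 60 min, tested at 1 uM; a lower number here means less inhibition, a higher number more inhibition at the concentration tested (going by the name of the read-out). Compound 2 gives 25%, the higher of the two numbers, while compound 1 `CCCOC(=O)C1=C(C)NC(=S)NC1c1ccco1` gives 1%, a gap beyond the usual scatter, although these two differ in more than one place. Compound 3 `CCCOC(=O)C1=C(C)NC(=S)NC1c1ccoc1` is not yet measured. It differs from compound 2 in a single spot: ethyl in place of hydrogen on a saturated chain carbon bound to an oxygen next to a carbonyl group, taking methoxycarbonyl to propoxycarbonyl. Among the compounds with values here, no single-change step among the measured compounds shows what this does. A modest fall is expected, a number 10 percentage points lower from compound 2 to compound 3 (within the scatter). Compound 3 is estimated at 15%, within 2% to 35%.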

Compound 3, a percentage reported as inhibition, at one concentration (the size of the read-out at that concentration, not a potency): 4%
Compound 3: middle estimate off by 11 percentage points, on the high side; measured number inside the range.
By their numbers in this assay, from the lowest: compounds 1 and 3 (each within the scatter of the next); then compound 2.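

In this assay the ester chain matters: with ethyl in place of hydrogen, taking methoxycarbonyl to propoxycarbonyl, the result is a number 21 percentage points lower from compound 2 to compound 3 (beyond the scatter). With the propoxycarbonyl group kept, furan-3-yl in place of furan-2-yl gives a number 3 percentage points higher from compound 1 to compound 3 (within the scatter), so this ring swap makes no readable difference here. Nothing available explains either step.

Still open, going by these compounds, is where along the chain the number falls, as ethoxycarbonyl could sit with either compound 2 or compound 3. On these data alone, whether a butyl chain or a carboxylic acid at this place would lower the number further also remains unknown.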